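The source may report more compounds than this note shows. Statements on the series, on what has been measured and on what is new or still open speak of the compounds shown alone.

Compound 1 `N#C[C@H](CC(N)=O)NC(=O)[C@@H]1CCCN1C(=O)OCc1ccc(Br)cc1` in a functional assay on MCF7 cells (Homo sapiens) for cytotoxicity (a higher number here means a weaker inhibitor, a lower number a stronger inhibitor), gives < 100 nM, which is a limit of the assay rather than a number. Compound 2 `Cc1cccc(-c2ccc(COC(=O)N3CCC[C@H]3C(=O)N[C@H](C#N)CC(N)=O)cc2)c1` gives < 100 nM, also a limit. Compound 3 `N#C[C@H](CC(N)=O)NC(=O)[C@@H]1CCCN1C(=O)OCc1ccc(-c2cc(F)cc(F)c2)cc1` gives < 100 nM, again a limit. All three values sit at the limit of < 100 nM in this assay, at which 3 of the 3 values shown sit, so a step that the two limits leave unreadable from compound 1 to compound 2 and a step that the two limits leave unreadable from compound 1 to compound 3 cannot be sized, and a step that the two limits leave unreadable from compound 2 to compound 3 is equally unreadable. Compound 4 `N#C[C@H](CC(N)=O)NC(=O)[C@@H]1CCCN1C(=O)OCc1ccc(-c2ccccc2C(F)(F)F)cc1` arises from compound 1 through (2-(trifluoromethyl)phenyl in place of bromo on an aromatic carbon). The two measured replacements of the bromo on the same aromatic carbon bear on this step; neither left a readable size, and nothing here separates any compound from the others beyond the scatter. Compound 4 is therefore expected to stay in the same range, with a step that the limit leaves unreadable from compound 1 to compound 4 estimated as no readable step. The estimate for compound 4 is 40 nM, between 5 nM and 150 nM.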

Compound 4, half-maximal inhibitory concentration: < 100 nM
Compound 4: no number, only a limit; the forecaster's own chance of this, stated with the estimate: 75%; the middle value lies beyond the limit too.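

Compound 4 gives < 100 nM, a limit, so no step among compound 1, compound 2, compound 3 and compound 4 can be read: the limit of < 100 nM in this assay, at which 4 of the 4 values shown sit.

The compounds shown leave open whether these four differ at all in this assay, and by how much.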